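Furan-3-yl in place of iodo on the nucleoside core

This account rests on a few compounds, and the source may have more. Where it says the series, first, only, none or still open, it means among the compounds named here.

Potency is followed in a functional assay on K562 cells (Homo sapiens), read by MTT assay, with a stated time of 72 h; a lower number here means a stronger inhibitor, a higher number a weaker inhibitor. Compound 2 `Cc1ncnc2c1c(I)cn2[C@@H]1O[C@H](CO)[C@@H](O)[C@H]1O` gives 17800 nM in this assay and stands as the only numerical result in the set. Compound 1 `Nc1nc(N)c2c(-c3ccsc3)cn([C@@H]3O[C@H](CO)[C@@H](O)[C@H]3O)c2n1` reaches only a limit in this assay, > 20000 nM, rather than a number. Compound 3 `Cc1nc(N)c2c(-c3cccs3)cn([C@@H]3O[C@H](CO)[C@@H](O)[C@H]3O)c2n1` likewise stops at a limit, > 20000 nM. For the measured compounds named here, two of the three values therefore sit at the limit of > 20000 nM in this assay, at which 2 of the 3 values shown sit, so no step between measured compounds is available to calibrate the change.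

Compound 4 `Cc1ncnc2c1c(-c1ccoc1)cn2[C@@H]1O[C@H](CO)[C@@H](O)[C@H]1O` is not yet measured. It differs from compound 2 as follows: furan-3-yl in place of iodo on an aromatic carbon. Going by the values given here, with no measured step of this kind on the core, the expectation for the move from compound 2 to compound 4 in this assay is a step of a 1.4-fold higher number from compound 2 to compound 4 (0.15 log units; within the scatter), most likely toward weaker inhibition, with the chance that only a limit is returned. Compound 4 is expected to give about 25000 nM, in the range 7000 nM to 90000 nM.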

Compound 4, half-maximal inhibitory concentration: > 20000 nM
Compound 4: no number, only a limit; the forecaster's own chance of this, stated with the estimate: 60%; the middle value does not contradict the limit.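

In this assay compound 4 gives > 20000 nM, which is a limit and not a number. Furan-3-yl in place of iodo on this aromatic carbon, two ring bonds from the ring nitrogen, is the first single-place change in the series that can be read, and it reads only as an at least 1.1-fold higher number from compound 2 to compound 4 (0.05 log units; that floor lies within the scatter); this gives no sign of stronger inhibition, and whether inhibition is any weaker stays unknown. The limit now dominates the series, which restricts what further comparisons can show: the limit of > 20000 nM in this assay, at which 3 of the 4 values shown sit.

On these data alone, whether an amine or a carboxylic acid on this aromatic carbon would return a number rather than a limit stays open. Also open, as far as these compounds go, is whether any group at this place can move the read-out beyond the scatter from compound 2.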